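Methyl in place of 5-chlorothiophen-2-yl

A few compounds are considered here, and "the series" means these few. Any claim that something is new, unique, unknown or untested is made for them only; others in the source may bear on it.

Compound 1 `Cc1nn(C)c2nc(NNC(=O)Nc3cc(Cl)nc(Cl)c3)cc(C3CC3)c12` gives 80800 nM
Compound 2 `Cc1nn(C)c2nc(NNC(=O)Nc3cc(Cl)nc(Cl)c3)cc(C3CCCCC3)c12` gives 22000 nM
Compound 3 `Cc1nn(C)c2nc(NNC(=O)Nc3cc(Cl)nc(Cl)c3)cc(-c3ccc(Cl)s3)c12` gives 29400 nM

In a functional assay on SW620/5-FU cells (Homo sapiens) for cytotoxicity, read by MTT assay, with a stated time of 48 h, in the presence of a further agent that is not named here (on this read-out lower numbers stand for an effect already at smaller amounts and higher numbers for an effect only at larger amounts of compound), compound 3 gives 29400 nM and stays level with compound 2, with a 1.3-fold higher number from compound 2 to compound 3 (0.13 log units; within the scatter) on record. Compound 4 `Cc1cc(NNC(=O)Nc2cc(Cl)nc(Cl)c2)nc2c1c(C)nn2C` differs from it by methyl in place of 5-chlorothiophen-2-yl on an aromatic carbon in all: methyl in place of 5-chlorothiophen-2-yl on an aromatic carbon. Among the measured compounds shown here, no measured step makes this exact change. Two modest steps at the same place bear on it, a 3.7-fold lower number from compound 1 to compound 2 (0.56 log units; beyond the scatter) and a 2.7-fold lower number from compound 1 to compound 3 (0.44 log units; beyond the scatter) as well, both leading away from cyclopropyl. A modest rise back toward the number of compound 1 is therefore expected in this assay for methyl. The expected change is a 2.2-fold higher number from compound 3 to compound 4 (0.34 log units; beyond the scatter) by this estimate. Compound 4 is estimated at 65000 nM with a range from 25000 nM to 170000 nM overall.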

Compound 4, half-maximal effective concentration: > 100000 nM
Compound 4 gave a limit, no number; the forecaster's own chance of this, stated with the estimate: 15%; middle value at least 1.5-fold (0.18 log units) from the limit.
By their numbers in this assay, from the lowest: compounds 2 and 3 (each within the scatter of the next); then compound 1. At a limit, above all of these: compound 4.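

Compound 4 gives > 100000 nM in this assay as a limit and no number. At this position on the shared core, methyl, which has no ring, thus stands apart from 5-chlorothiophen-2-yl and cyclohexyl, with an at least 3.4-fold higher number from compound 3 to compound 4 (0.53 log units; beyond the scatter) and an at least 4.5-fold higher number from compound 2 to compound 4 (0.65 log units; beyond the scatter) as steps. Methyl is not separated from cyclopropyl, however: an at least 1.2-fold higher number from compound 1 to compound 4 (0.09 log units; that floor lies within the scatter) is the only reading available for that pair, and it gives no order.

On these data alone, what an amine or a longer alkyl chain would do at this position stays open. So does the actual value of compound 4 beyond its limit.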